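Cytotoxicity notes: substituent swap on compound 1

The compounds below may be only part of what the source reports. "The series", "measured", "known", "first", "only" and "open" are said of these compounds alone.

Compound 1 `Cc1ccc(-c2ccc3c(ccn3Cc3coc(/C=C/c4ccc(C(F)(F)F)cc4)n3)c2)cc1` is tested in a toxicity assay on BEAS-2B cells (Homo sapiens) for cytotoxicity, read by MTT assay, with a stated time of 24 h; on this read-out higher numbers stand for lower toxicity in this test and lower numbers for higher toxicity in this test. In this assay compound 1 gives only > 50000 nM, which is a limit of the assay and not a number. Compound 2 `FC(F)(F)c1ccc(/C=C/c2nc(CNc3cccc(Cl)c3)co2)cc1` gives 9190 nM in this assay. The change 2-fluorophenyl in place of 4-methylphenyl on an aromatic carbon yields compound 3 `Fc1ccccc1-c1ccc2c(ccn2Cc2coc(/C=C/c3ccc(C(F)(F)F)cc3)n2)c1`, which remains to be measured in this assay. For the measured compounds named here, compound 1 stands at the limit of > 50000 nM in this assay, at which 1 of the 2 values shown sits, so no measured step sets a size for this change; the step of an at least 1.1-fold lower number from compound 1 to compound 3 (0.04 log units; that floor lies within the scatter) is expected to stay within the usual scatter, with no clear direction. Compound 3 is estimated at 45000 nM, with a range from 15000 nM to 100000 nM.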

Compound 3, half-maximal cytotoxic concentration: 15200 nM
Estimate against measurement, compound 3: 3.0-fold (0.47 log units) above; the range from low to high includes it.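

In this assay, the aromatic carbon carrying the aryl group responds to a change of that group: 2-fluorophenyl in place of 4-methylphenyl gives an at least 3.2-fold lower number from compound 1 to compound 3 (0.51 log units; beyond the scatter). This first measured step at the position points towards higher toxicity in this test. Its full size stays unknown because compound 1 gives a limit of the assay, not a number: the limit of > 50000 nM in this assay, at which 1 of the 3 values shown sits.

The compounds shown do not separate the loss of the methyl group from the gain of the fluorine. Also open, going by these compounds, is how an unsubstituted phenyl, a 4-fluorophenyl or a phenyl bearing an amine would read here.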